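Fluoro in Place of Chloro: Estimating Compound 3

The source may hold more compounds than are shown below. What is called first, only, known or untested is meant among the compounds shown, and "the series" means these compounds.

Measured compounds:
compound 1 `COc1cc2ncnc(NNC(=S)NC(=O)c3ccccc3Cl)c2cc1OC` — 23100 nM
compound 2 `O=C(NC(=S)NNc1ncnc2ccccc12)c1ccc(Cl)cc1` — 5960 nM

Of the compounds shown here, two have been measured in a functional assay on MCF7 cells (Homo sapiens) for cytotoxicity, read by MTT assay, with a stated time of 72 h; on this read-out lower numbers stand for stronger inhibition and higher numbers for weaker inhibition. Compound 1 gives 23100 nM, the higher of the two numbers; compound 2 gives 5960 nM, and this gap lies beyond the usual scatter. Within the data shown here, the two measured compounds differ in more than one place, so no single measured step is available to guide the change considered here.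

Compound 3 `COc1cc2ncnc(NNC(=S)NC(=O)c3ccccc3F)c2cc1OC` differs from compound 1 in exactly one place: fluoro in place of chloro on an aromatic carbon. One halogen atom is exchanged for another, with the rest of the molecule untouched. Without a measured step of this kind to lean on, the step of a 1.2-fold lower number from compound 1 to compound 3 (0.06 log units; within the scatter) is expected to be small, with no clear direction and probably within the scatter. Compound 3 is therefore estimated at 20000 nM, with a likely range from 8000 nM to 50000 nM.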

Compound 3, half-maximal inhibitory concentration: 8500 nM
Beside the measured number, compound 3's estimate is 2.4-fold (0.37 log units) above it; low and high end bracket the measured number.
By their numbers in this assay, from the lowest: compounds 2 and 3 (each within the scatter of the next); then compound 1.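

Exchanging one halogen for another at this position is not a neutral change: in this assay, going from the 2-chlorophenyl group to the 2-fluorophenyl group gives a 2.7-fold lower number from compound 1 to compound 3 (0.43 log units; beyond the scatter). Among these compounds, this is the only measured step at this place, on an aromatic carbon ortho to a large group, and it shows that a change of a single atom there can move the number beyond the usual scatter, with fluoro giving the lower number. No measurement of any property of these groups bears on the result, so the step stands as an observation without an established cause.

The compounds shown leave open whether a halogen is needed here at all, which a hydrogen, a methyl group or an amine at the same carbon would help to settle. On these data alone, whether the same exchange gives a similar step on a different core also remains open.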